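Benzoylcarbamoyl in Place of a Keto Ester Chain

The source may report more compounds than this note shows. Statements on the series, on what has been measured and on what is new or still open speak of the compounds shown alone.

Compound 1 `COC(=O)C(=O)CNC1=CS(=O)(=O)O[C@@]12[C@@H](CO[Si](C)(C)C(C)(C)C)O[C@@H](n1cc(C)c(=O)n(C)c1=O)[C@@H]2O[Si](C)(C)C(C)(C)C` was tested in a functional assay on HEL cells (Homo sapiens); a higher number here means that more compound is tolerated, a lower number that less compound is tolerated. There compound 1 gives > 200000 nM, which is a limit of the assay rather than a number. Compound 2 `Cc1cn([C@@H]2O[C@H](CO[Si](C)(C)C(C)(C)C)[C@@]3(OS(=O)(=O)C=C3NCC(=O)OCc3ccccc3)[C@H]2O[Si](C)(C)C(C)(C)C)c(=O)n(C)c1=O` gives > 200000 nM, again a limit. Compound 3 `COC(=O)NC1=CS(=O)(=O)O[C@@]12[C@@H](CO[Si](C)(C)C(C)(C)C)O[C@@H](n1cc(C)c(=O)n(C)c1=O)[C@@H]2O[Si](C)(C)C(C)(C)C` gives > 200000 nM, also a limit. The steps a step that the two limits leave unreadable from compound 1 to compound 2 and a step that the two limits leave unreadable from compound 1 to compound 3 are therefore unreadable, as is a step that the two limits leave unreadable from compound 2 to compound 3; all three values sit at the limit of > 200000 nM in this assay, at which 3 of the 3 values shown sit. Compound 4 `Cc1cn([C@@H]2O[C@H](CO[Si](C)(C)C(C)(C)C)[C@@]3(OS(=O)(=O)C=C3NC(=O)NC(=O)c3ccccc3)[C@H]2O[Si](C)(C)C(C)(C)C)c(=O)n(C)c1=O` differs from compound 1 by benzoylcarbamoyl in place of ((methoxycarbonyl)carbonyl)methyl on an amine nitrogen. No measured change at the amine nitrogen moved the read-out off the limit, so the step that the limit leaves unreadable from compound 1 to compound 4 is expected to be none beyond the scatter, most likely ending in another limit. Compound 4 is thus estimated at 250000 nM, within 100000 nM to 600000 nM.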

Compound 4, half-maximal cytotoxic concentration: >= 200000 nM
Compound 4 ended at the assay's limit; the forecaster's own chance of this, stated with the estimate: 80%; the middle value lies beyond the limit too.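

Compound 4 gives >= 200000 nM, a limit of this assay. Its steps to compound 1, compound 2 and compound 3, which also sit at limits, cannot be read. The compounds shown leave open at what concentration any of them harms these cells, and whether any change at the amine nitrogen matters.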